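The source may hold more compounds than are shown below. What is called first, only, known or untested is meant among the compounds shown, and "the series" means these compounds.

Measured compounds:
compound 1 `N#Cc1ccc2nc(-c3cccnc3)n(C3CC3)c2c1` in an assay on V79 cells for inhibition of cytochrome P450 11B1, mitochondrial (Homo sapiens), read by HTRF, with a stated time of 1 h (on this read-out lower numbers stand for stronger inhibition and higher numbers for weaker inhibition), gives 374 nM
compound 2 `Fc1ccc2nc(-c3cccnc3)[nH]c2c1` in this assay gives 1990 nM

Of the two compounds measured, compound 2 stands with the highest number, that is the weakest inhibition; its nearest neighbour, compound 1, shows a lower number in this assay, and the gap between the two lies beyond the usual scatter of repeated measurements. The two compounds differ in more than one place, so their values alone do not show what each change contributes.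

Compound 3 `Fc1ccc2nc(-c3cccnc3)n(C3CC3)c2c1` has not yet been measured. It differs from compound 2 by one change: cyclopropyl in place of hydrogen on an aromatic nitrogen. Within the data shown here, no single-change step between measured compounds is available, so the size of the effect of this change is not known from the data. Since compound 1, which carries the same cyclopropyl on the ring nitrogen, gives 374 nM, the change is expected to lower the number, and a step of a 3.3-fold lower number from compound 2 to compound 3 (0.52 log units; beyond the scatter) is estimated. For compound 3 an estimate of 600 nM is given, with a range from 150 nM to 2400 nM.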

Compound 3, half-maximal inhibitory concentration: 401 nM
Estimate against measurement, compound 3: 1.5-fold (0.18 log units) above, and the stated range covers the measured number.
By their numbers in this assay, from the lowest: compounds 1 and 3 (each within the scatter of the next); then compound 2.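

In this assay, among these compounds, cyclopropyl in place of hydrogen on an aromatic nitrogen gives a 5.0-fold lower number from compound 2 to compound 3 (0.70 log units; beyond the scatter), the first single-change reading at this position; the earlier pair differed in more than one place and could not separate it. Fluoro in place of cyano on an aromatic carbon gives a 1.1-fold higher number from compound 1 to compound 3 (0.03 log units; within the scatter), so with cyclopropyl on the nitrogen, this assay does not tell these two groups apart. No measurement is available that explains either step.

The compounds shown leave open whether a longer chain or a benzyl group on this nitrogen would lower the number further than cyclopropyl does. They also leave open how an amine or a carboxylic acid would read on the aromatic carbon that carries fluoro or cyano.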